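A few compounds are considered here, and "the series" means these few. Any claim that something is new, unique, unknown or untested is made for them only; others in the source may bear on it.

Compound 1 `CC(C)c1cc(C(C)(C)C)cc(-c2ccc(F)cc2)c1CO`: 740 nM
Compound 2 `Cc1ccccc1-c1cc(C(C)(C)C)cc(C(C)C)c1CO`: > 50000 nM
Compound 3 `CC(C)c1cc(C(C)(C)C)cc(-c2cccc(C(F)(F)F)c2)c1CO`: > 50000 nM

Among the measured compounds shown here, in a functional assay on RKE cells for antagonist activity at Vasoactive intestinal polypeptide receptor 1 (Rattus norvegicus), read by HTRF and cAMP accumulation, with stated times of 10 min and 30 min (a lower number here means a stronger inhibitor, a higher number a weaker inhibitor), compound 1 gives 740 nM, the only actual number among the three measured compounds. For compound 2 the result is a limit of the assay, > 50000 nM. For compound 3 the result is likewise a limit, > 50000 nM. Compound 4 `COc1ccc(-c2cc(C(C)(C)C)cc(C(C)C)c2CO)cc1` has not yet been measured; it differs from compound 1 by methoxy in place of fluoro on an aromatic carbon. For the measured compounds named here, only one measured step bears on this change, and it alters the same aryl group: an at least 67-fold higher number from compound 1 to compound 2 (1.82 log units; beyond the scatter), a large loss. Because an at least 67-fold higher number from compound 1 to compound 2 (1.82 log units; beyond the scatter) is large and compound 3 also sits at the limit of > 50000 nM in this assay, at which 2 of the 3 values shown sit, compound 4 is expected to be weaker than compound 1, a 4.1-fold higher number from compound 1 to compound 4 (0.61 log units; beyond the scatter), with an estimate of 3000 nM, in a range from 500 nM to 30000 nM.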

Compound 4, half-maximal inhibitory concentration: 1300 nM
The estimate for compound 4 lay 2.3-fold (0.36 log units) above the measured number; measured number inside the range.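

In this assay, methoxy in place of fluoro, para to a large group, gives a 1.8-fold higher number from compound 1 to compound 4 (0.24 log units; within the scatter), so the two groups cannot be told apart here. Among the compounds shown here, the only earlier step on this aryl group, an at least 67-fold higher number from compound 1 to compound 2 (1.82 log units; beyond the scatter), was a large loss, so not every change to that aryl group costs this much. Nothing shown here explains why methoxy and fluoro read alike. Still open, on these data alone, is how an amine or a carboxylic acid in place of fluoro would read. The same holds for a longer chain such as ethoxy.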